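This account rests on a few compounds, and the source may have more. Where it says the series, first, only, none or still open, it means among the compounds named here.

In a functional assay on MCF7 cells (Homo sapiens) for cytotoxicity, read by MTT assay, with a stated time of 48 h (on this read-out lower numbers stand for stronger inhibition of growth and higher numbers for weaker inhibition of growth), compound 1 (`Cn1c(C(F)(F)F)nc2cc(Cl)c(Cl)cc21`) gives 39000 nM and compound 2 (`CCn1c(C(F)(F)F)nc2cc(Cl)c(Cl)cc21`) gives 72900 nM. Compound 3 (`Clc1cc2ncn(C3CCCC3)c2cc1Cl`) gives 42000 nM, which lies within the scatter of both, so these three numbers cannot be ranked. Compound 4 (`CC(C)c1nc2cc(Cl)c(Cl)cc2n1C1CCCC1`) has isopropyl in place of hydrogen on an aromatic carbon of compound 3: isopropyl in place of hydrogen on an aromatic carbon. Going by the values given here, no measured step makes this exact change. The only one available, a 1.9-fold higher number from compound 1 to compound 2 (0.27 log units; within the scatter), lies within the scatter and concerns a methyl in place of hydrogen on a saturated chain carbon bound to an aromatic nitrogen, so it bears on this change only loosely. More useful is compound 1, which carries trifluoromethyl on the matching carbon and gives 39000 nM, within the scatter of compound 3, although the two also differ in the group on nitrogen. No shift beyond the scatter is therefore expected in this assay. The expected result is a 1.1-fold higher number from compound 3 to compound 4 (0.03 log units; within the scatter). For compound 4 the estimated value is 45000 nM, with an expected range from 20000 nM to 90000 nM.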

Compound 4, concentration for 50% growth inhibition: 43000 nM
Compound 4: the middle estimate sits 1.0-fold (0.02 log units) above what was measured; measured number inside the range.
By their numbers in this assay, from the lowest: compounds 1, 3, 4 and 2 (each within the scatter of the next).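

In this assay, isopropyl in place of hydrogen on the aromatic carbon between two ring nitrogen atoms, next to the ring atom that bears a cyclopentyl group, gives a 1.0-fold higher number from compound 3 to compound 4 (0.01 log units; within the scatter), so the change stays within the scatter. This is the first pair shown that differs only at this carbon, and it indicates that, with cyclopentyl on the neighbouring ring atom, this position accepts a group of 3 heavy atoms without a measurable shift in growth inhibition. Nothing available explains this lack of a shift.

The compounds shown leave open whether an amine or a carboxylic acid on this carbon, or a longer chain in place of isopropyl, would move the number beyond the scatter. They also leave open whether a phenyl ring there would do so.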